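The source may report more compounds than this note shows. Statements on the series, on what has been measured and on what is new or still open speak of the compounds shown alone.

Three compounds of the series have so far been run in an ADME assay on isolated protein for inhibition of Dipeptidyl peptidase 9 (Homo sapiens), with stated times of 15 min, 60 s and 20 min; on this read-out higher numbers stand for weaker inhibition and lower numbers for stronger inhibition. Compound 1 `CC#CCn1c(N2CCC[C@@H](N)C2)nc2c1c(=O)n(Cc1ccc(Br)cc1C(=O)OC)c(=O)n2C` gives > 100000 nM, which is a limit of the assay and not a number. Compound 2 `CC#CCn1c(N2CCC[C@@H](N)C2)nc2c1c(=O)n(Cc1cccc(F)c1C(=O)O)c(=O)n2C` likewise returns only a limit, > 100000 nM. Compound 3 `CC#CCn1c(N2CCC[C@@H](N)C2)nc2c1c(=O)n(Cc1ccc(Br)cc1C(=O)OCC)c(=O)n2C` also sits at a limit, > 100000 nM. The steps among these three are unreadable: a step that the two limits leave unreadable from compound 1 to compound 2, a step that the two limits leave unreadable from compound 1 to compound 3 and a step that the two limits leave unreadable from compound 2 to compound 3 cannot be sized, since (the limit of > 100000 nM in this assay, at which 3 of the 3 values shown sit). Compound 3 thus stands where compounds 1 and 2 stand, at the limit of this assay, with no number beneath it.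

Compound 4 `CC#CCn1c(N2CCC[C@@H](N)C2)nc2c1c(=O)n(Cc1ccccc1C(=O)OC)c(=O)n2C` differs from compound 3 by 2-(methoxycarbonyl)phenyl in place of 4-bromo-2-(ethoxycarbonyl)phenyl on a saturated chain carbon bound to an aromatic nitrogen. For the measured compounds named here, none of the measured steps bears on this change with a readable size, because the limit of > 100000 nM in this assay, at which 3 of the 3 values shown sit, holds for every value shown. The expectation for compound 4 is therefore a step that the limit leaves unreadable from compound 3 to compound 4 in this assay, most probably ending again at a limit rather than a number. Compound 4 is estimated at 150000 nM, with a range from 30000 nM to 1000000 nM.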

Compound 4, half-maximal inhibitory concentration: > 100000 nM
Compound 4: no number, only a limit; the forecaster's own chance of this, stated with the estimate: 85%; the middle value is on the limit's open side.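

In this assay compound 4 gives > 100000 nM, a limit and not a number. No step linking compound 4 with compound 1, compound 2 or compound 3 can be read: the limit of > 100000 nM in this assay, at which 4 of the 4 values shown sit.

The compounds shown leave open whether any of these changes alters inhibition at all.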